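Cytotoxicity of a Cyclic Peptide Series: Removing One Methyl

The compounds below may be only part of what the source reports. "The series", "measured", "known", "first", "only" and "open" are said of these compounds alone.

Compound 1 `C/C=C1\NC(=O)[C@@H](C)NC(=O)CNC(=O)[C@](C)(C(C)=O)NC(=O)[C@H](Cc2c[nH]c3cccc(OC)c23)NC(=O)c2csc(n2)[C@@H](C)NC(=O)CNC1=O` gives > 200000 nM in a toxicity assay on Huh-7.5 cells (Homo sapiens) for cytotoxicity (a higher number here means that more compound is tolerated, a lower number that less compound is tolerated), a limit of the assay.
Compound 2 `C/C=C1\NC(=O)[C@@H](CC)NC(=O)CNC(=O)[C@](C)(C(C)=O)NC(=O)[C@H](Cc2c[nH]c3cccc(OC)c23)NC(=O)c2csc(n2)[C@@H](C)NC(=O)CNC1=O` gives > 105000 nM in this assay, a limit.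
Compound 3 `C/C=C1\NC(=O)[C@@H](CC)NC(=O)CNC(=O)[C@](C)(C(C)=O)NC(=O)[C@H](Cc2c[nH]c3cccc(OC)c23)NC(=O)c2csc(n2)[C@@H](C)NC(=O)CN(C)C1=O` gives > 111000 nM in this assay, a limit.

Among the compounds with values here, all three measured values are limits, so no compound shows measurable toxicity within the tested range. Compound 3 therefore stands at a limit, as do the other two values shown, and nothing ranks it against compound 1 or compound 2.

Compound 4 `C/C=C1\NC(=O)[C@@H](C)NC(=O)CNC(=O)[C@](C)(C(C)=O)NC(=O)[C@H](Cc2c[nH]c3cccc(OC)c23)NC(=O)c2csc(n2)[C@@H](C)NC(=O)CN(C)C1=O` is not yet measured. It differs from compound 3 by hydrogen in place of methyl on a saturated chain carbon bound to a saturated ring carbon.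

The step that the two limits leave unreadable from compound 1 to compound 2 is the reverse of this change, with the same group at the same place, but both ends are limits and its size cannot be read. The step that the two limits leave unreadable from compound 2 to compound 3 is likewise unreadable. Within the data shown here, the evidence (the limit of > 105000 nM in this assay, at which 1 of the 3 values shown sits), the limit of > 111000 nM in this assay, at which 1 of the 3 values shown sits, and the limit of > 200000 nM in this assay, at which 1 of the 3 values shown sits, shows only that every compound so far was tolerated up to the highest concentration tested.

Given this, compound 4 is expected to remain beyond the assay range as well, so the step that the limit leaves unreadable from compound 3 to compound 4 is estimated as none beyond the scatter. Compound 4 is expected to give 200000 nM, with a range from 100000 nM to 400000 nM, most likely reported again only as a limit.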

Compound 4, half-maximal cytotoxic concentration: > 36500 nM
Compound 4: a limit, no number; the forecaster's own chance of this, stated with the estimate: 90%; the middle value lies beyond the limit too.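

Compound 4, like compound 1 and compound 3, gives only a limit, so neither new step, from compound 3 or from compound 1 to compound 4, can be read. In this assay the compounds shown leave open how much of each is actually tolerated, and whether either methyl changes that.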